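The compounds below may be only part of what the source reports. "The series", "measured", "known", "first", "only" and "open" are said of these compounds alone.

Measured so far:
- Compound 1 `CS(=O)(=O)NC(=O)CCc1cn(-c2cccc(Br)c2)nc1-c1ccc(Cl)cc1`: < 5000 nM (a limit)
- Compound 2 `CS(=O)(=O)NC(=O)CCc1cn(-c2ccc(Cl)cc2)nc1-c1ccc(Cl)cc1`: 100000 nM

For the measured compounds named here, in a physicochemical assay for solubility, in phosphate buffer, measured as thermodynamic solubility, at pH 7.4 (on this read-out lower numbers stand for lower solubility and higher numbers for higher solubility), compound 2 gives 100000 nM, the only exact number so far. Compound 1 gives < 5000 nM, which is a limit and not a number. Compound 3 `CS(=O)(=O)NC(=O)CCc1cn(-c2ccc(C#N)cc2)nc1-c1ccc(Cl)cc1` differs from compound 2 by cyano in place of chloro on an aromatic carbon. Going by the values given here, the one measured step, an at least 20-fold higher number from compound 1 to compound 2 (1.30 log units; beyond the scatter), is large and also concerns the 4-chlorophenyl group, but it gives no direction for cyano. The expected step is a 1.2-fold higher number from compound 2 to compound 3 (0.08 log units; within the scatter), with no change beyond the scatter foreseen. For compound 3 the estimate is 120000 nM, with an expected range of 30000 nM to 400000 nM.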

Compound 3, solubility: 75000 nM
Estimate against measurement, compound 3: 1.6-fold (0.20 log units) above; measured number inside the range.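

In this assay, cyano in place of chloro on this aromatic carbon gives a 1.3-fold lower number from compound 2 to compound 3 (0.12 log units; within the scatter), so no real change can be read between these two groups. Moving away from the 3-bromophenyl group now gives a large step with a second group, an at least 15-fold higher number from compound 1 to compound 3 (1.17 log units; beyond the scatter). The value of compound 1 is a limit and not a number: the limit of < 5000 nM in this assay, at which 1 of the 3 values shown sits.

Still open, as far as these compounds go, is whether an amine or a carboxylic acid at this place would behave like chloro and cyano. A 4-bromophenyl group could also show whether the bromine or its place on the ring sets compound 1 apart.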